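Chloro-to-hydrogen step carried from one bicyclic core to another

The compounds below may be only part of what the source reports. "The series", "measured", "known", "first", "only" and "open" are said of these compounds alone.

Measured so far in a functional assay on the whole organism with Scenedesmus acutus as the target, with a stated time of 20 h; a higher number here means a weaker inhibitor, a lower number a stronger inhibitor:
compound 1, `S=c1n(-c2ccc(Cl)cc2)c(=S)n2n1CCCC2`: 50.1 nM
compound 2, `S=c1n(-c2ccccc2)c(=S)n2n1CCCC2`: 2040 nM
compound 3, `S=c1s/c(=N\c2ccc(Cl)cc2)n2n1CCCC2`: 550 nM

Compound 2 differs from compound 1 by hydrogen in place of chloro on an aromatic carbon and the step is large: a 41-fold higher number from compound 1 to compound 2 (1.61 log units; beyond the scatter). Compound 3 has the same atoms as compound 1 joined differently; the difference between the two cores is not broken down here. In this assay compound 3 stands between the other two, above compound 1 and below compound 2.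

Compound 4, `S=c1s/c(=N\c2ccccc2)n2n1CCCC2`, is not yet measured. It differs from compound 3 by hydrogen in place of chloro on an aromatic carbon, the same change as from compound 1 to compound 2. The expected step is an 18-fold higher number from compound 3 to compound 4 (1.26 log units; beyond the scatter); this rests on the single earlier occurrence, a 41-fold higher number from compound 1 to compound 2 (1.61 log units; beyond the scatter), seen on a different core, so a weaker echo is assumed. Compound 4 is expected to give about 10000 nM, probably between 2500 nM and 50000 nM.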

Compound 4, half-maximal inhibitory concentration: 4370 nM
Beside the measured number, compound 4's estimate is 2.3-fold (0.36 log units) above it; low and high end bracket the measured number.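

In this assay, hydrogen in place of chloro on an aromatic carbon again gives a weaker inhibitor, here with a 7.9-fold higher number from compound 3 to compound 4 (0.90 log units; beyond the scatter). The direction carries from one core to the other, but the size does not, as the two steps differ by more than the scatter: the same change on two cores in this assay, a 41-fold higher number (1.61 log units; beyond the scatter) from compound 1 to compound 2 and a 7.9-fold higher number (0.90 log units; beyond the scatter) from compound 3 to compound 4, 5.1-fold (0.71 log units) apart, beyond the scatter of two such steps

Within the data shown here, with only two cores, this does not give a typical size for the change on any further core, and it does not show what about the cores sets the gap.

Open, going by these compounds, is whether other groups in the same place, such as bromo, methoxy or nitrile, would act in the same direction on both cores. Also open, on these data alone, is whether the gap between the cores would persist with those groups.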